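A few compounds are considered here, and "the series" means these few. Any claim that something is new, unique, unknown or untested is made for them only; others in the source may bear on it.

Measured compounds:
compound 1 `C=C1/C=C/C(=O)/C(CO)=C\C[C@](C)(CCC=C(C)C)/C=C/[C@H]1OC(=O)C=C(C)C` — 2970 nM
compound 2 `CC(C)=CCC[C@]1(C)/C=C/[C@@H](OC(=O)C=C(C)C)[C@](C)(O)/C=C/C(=O)/C(CN(C(C)C)C(C)C)=C\C1` — 750 nM
compound 3 `CC(C)=CCC[C@]1(C)/C=C/[C@@H](OC(=O)C=C(C)C)[C@](C)(O)/C=C/C(O)/C(C=O)=C\C1` — 1430 nM

In a functional assay on SW480 cells (Homo sapiens) for antiproliferative activity, read by MTT assay, with a stated time of 48 h (a lower number here means a stronger inhibitor, a higher number a weaker inhibitor), compound 2 gives the lowest of the three numbers; compound 3 lies within the scatter of it, while compound 1 lies beyond the scatter, so compound 2 can only be said to sit below compound 1 with confidence. Compound 4 `CO/N=C/C1=C/C[C@](C)(CCC=C(C)C)/C=C/[C@@H](OC(=O)C=C(C)C)[C@](C)(O)/C=C/C1=O` differs from compound 2 in one place: a group of 4 heavy atoms (2 carbon, 1 nitrogen, 1 oxygen; no ring) in place of a group of 8 heavy atoms (7 carbon, 1 nitrogen; no ring), on a double-bonded ring carbon. For the measured compounds named here, no measured pair shows this change directly, so the expectation rests on compound 3, which carries a small oxygen-bearing group on the same ring carbon and gives 1430 nM. Compound 4 is therefore expected to give a somewhat higher number than compound 2, a step of a 2.0-fold higher number from compound 2 to compound 4 (0.30 log units; within the scatter), near the edge of the scatter. The estimate for compound 4 is 1500 nM, between 500 nM and 4500 nM.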

Compound 4, half-maximal inhibitory concentration: 2630 nM
The estimate for compound 4 lay 1.8-fold (0.24 log units) below the measured number; the measured number falls inside the stated range.
By their numbers in this assay, from the lowest: compounds 2, 3, 4 and 1 (each within the scatter of the next, the first and the last beyond it).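

For the compounds shown here, this is the first step read at this double-bonded ring carbon in this assay. Putting the group of 4 heavy atoms of compound 4 in place of the (diisopropylamino)methyl group gives a 3.5-fold higher number from compound 2 to compound 4 (0.54 log units; beyond the scatter), so the number responds to what this position carries. Nothing at hand accounts for the step. The compounds shown leave open whether the amine nitrogen or the size of the group matters here. A smaller amine such as (dimethylamino)methyl, or a cyclic amine such as piperidin-1-ylmethyl, on the same ring carbon would help separate the two.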